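Trifluoromethylphenyl Replaces Chlorophenyl on the Shared Core

A few compounds are considered here, and "the series" means these few. Any claim that something is new, unique, unknown or untested is made for them only; others in the source may bear on it.

Going by the values given here, compound 2 `Clc1ccc(-c2cn3ccnc3c(-c3ccc4ncn(C5CCCCC5)c4c3)n2)cc1` has the lower of the two numbers measured so far. In a functional assay on T47D cells (Homo sapiens) for inhibition, read by sulforhodamine B assay, with a stated time of 48 h, tested at 10 uM (a lower number here means less inhibition, a higher number more inhibition at the concentration tested (going by the name of the read-out)), compound 2 gives 27.6%, while compound 1 `CC(=O)c1ccc(-c2cn3ccnc3c(-c3ccc4ncn(C5CCCCC5)c4c3)n2)cc1` gives 54.4%. Among the compounds with values here, compound 2 thus holds the lowest of the two numbers, with compound 1 as its only neighbour, and the gap between them lies beyond the scatter.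

Compound 3 `FC(F)(F)c1cccc(-c2cn3ccnc3c(-c3ccc4ncn(C5CCCCC5)c4c3)n2)c1` has not yet been measured. It differs from compound 2 in one place: 3-(trifluoromethyl)phenyl in place of 4-chlorophenyl on an aromatic carbon. Within the data shown here, the only step measured so far, a number 26.8 percentage points lower from compound 1 to compound 2 (beyond the scatter), exchanges the group on the same aromatic carbon, so it shows that this position can move the number by a modest amount, though through a different exchange. Among the measured compounds shown here, no step involving a trifluoromethyl group has been measured, so the direction for compound 3 is open. Since compound 1 with acetyl gives 54.4% and compound 2 with chloro gives 27.6%, a move of similar size in either direction seems possible, and the central guess is no change beyond the scatter. Compound 3 is therefore expected to give 33%, within 10% to 60%, which would mean an expected step of a number 5.4 percentage points higher from compound 2 to compound 3 (within the scatter).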

Compound 3, a percentage reported as inhibition, at one concentration (the size of the read-out at that concentration, not a potency): 52.2%
Compound 3: the middle estimate sits 19.2 percentage points below what was measured, and the stated range covers the measured number.
By their numbers in this assay, from the lowest: compound 2; then compounds 3 and 1 (each within the scatter of the next).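

In this assay, going by these compounds alone, putting 3-(trifluoromethyl)phenyl in place of 4-chlorophenyl gives a number 24.6 percentage points higher from compound 2 to compound 3 (beyond the scatter), so this aromatic carbon responds to more than the one exchange seen earlier, even though both groups count 0 hydrogen-bond donors and 0 hydrogen-bond acceptors. Within the data shown here, the other new comparison, a number 2.2 percentage points lower from compound 1 to compound 3 (within the scatter), puts 3-(trifluoromethyl)phenyl and 4-acetylphenyl level within the scatter, which leaves compound 2 as the one compound of the three set apart from the others. Nothing measured here explains why these groups give such different numbers.

The step from compound 2 to compound 3 changes both the group on the phenyl ring and where that group sits, so the compounds shown cannot separate the effect of the group from the effect of its place on the ring. On these data alone, it also stays open whether a phenyl ring carrying an amine or a carboxylic acid on this same aromatic carbon would give a number close to that of compound 2 or close to those of compound 1 and compound 3.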